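This account rests on a few compounds, and the source may have more. Where it says the series, first, only, none or still open, it means among the compounds named here.

Working notes on the series. The shared core of compound 2 `CCN(Cc1cccs1)C(=O)COc1ccc(C(F)(F)F)cc1` carries an aryloxyacetamide with an ethyl group and a thienylmethyl group on the amide nitrogen. Among the compounds with values here, in an assay on HEK293 cells for agonist activity at transient receptor potential cation channel subfamily M member 8 (Homo sapiens), read by fluorescence and calcium flux, with a stated time of 15 min (a higher number here means that more compound is needed for the effect, a lower number that less compound is needed), compound 2 gives 236 nM, the highest of the three numbers so far. Its nearest neighbour is compound 1 `Cc1ccc(OCC(=O)N(Cc2cccs2)c2cccnc2)cc1`, which in this assay gives 198 nM; the two values lie within the scatter of each other, so no order is read from them. Within the data shown here, the furthest is compound 3 `CCN(Cc1cccs1)C(=O)/C=C/c1ccc(C)cc1`, which in this assay gives 2 nM, a number far below that of compound 2 and well beyond the scatter; compound 3 differs from compound 2 in more than one place, so no single step is assigned to the gap.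

Compound 4 `CCN(Cc1cccs1)C(=O)COc1ccc(OC)cc1` is the next variation on compound 2: methoxy in place of trifluoromethyl on an aromatic carbon. Among the measured compounds shown here, no measured pair in this assay isolates this kind of exchange, so the size of the step can only be guessed from the position of compound 2 itself. The expected step from compound 2 to compound 4 is a 1.1-fold higher number from compound 2 to compound 4 (0.03 log units; within the scatter), that is, none beyond the scatter in either direction. Compound 4 is therefore estimated at 250 nM, with a range from 60 nM to 1000 nM.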

Compound 4, half-maximal effective concentration: 120 nM
For compound 4 the middle estimate is 2.1-fold (0.32 log units) above the measured one; measured number inside the range.
By their numbers in this assay, from the lowest: compound 3; then compounds 4, 1 and 2 (each within the scatter of the next).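

In this assay the exchange of trifluoromethyl for methoxy on an aromatic carbon, para to a large group, gives a 2.0-fold lower number from compound 2 to compound 4 (0.29 log units; within the scatter), the first step measured at this position; it sets no order between the two compounds. Methoxy, with 2 heavy atoms and 1 hydrogen-bond acceptor, stands where trifluoromethyl stood with 4 heavy atoms and 0 hydrogen-bond acceptors, and the two numbers remain within the scatter of each other. No supporting evidence bears on the size of this step.

Open, going by these compounds, is whether another group at this position, such as an amine, a carboxylic acid or a longer alkoxy chain, would give a step beyond the scatter. Also open, on these data alone, is whether the same exchange gives a step of similar size on the core of compound 1.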